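This account rests on a few compounds, and the source may have more. Where it says the series, first, only, none or still open, it means among the compounds named here.

Three compounds share one core and differ only at the far end of a side chain that carries an amide. Compound 1 `CS(=O)(=O)N1CCc2c(c(-c3ccc(C(F)(F)F)c(SCCNC(=O)c4ccccc4)c3)nn2CC(O)CN2CCC(N3CCCC3=O)CC2)C1` gives 380 nM in an assay on isolated protein for inhibition of cathepsin S (Homo sapiens); a higher number here means a weaker inhibitor, a lower number a stronger inhibitor. Compound 2 `CS(=O)(=O)N1CCc2c(c(-c3ccc(C(F)(F)F)c(SCCNC(=O)c4ccc(F)cc4)c3)nn2CC(O)CN2CCC(N3CCCC3=O)CC2)C1` gives 360 nM in this assay, and compound 3 `CN(C)c1ccc(C(=O)NCCSc2cc(-c3nn(CC(O)CN4CCC(N5CCCC5=O)CC4)c4c3CN(S(C)(=O)=O)CC4)ccc2C(F)(F)F)cc1` gives 530 nM in this assay. Compound 3 is not set apart from the other two beyond the scatter, as a 1.4-fold higher number from compound 1 to compound 3 (0.14 log units; within the scatter) and a 1.5-fold higher number from compound 2 to compound 3 (0.17 log units; within the scatter) show. Compound 4 `CS(=O)(=O)N1CCc2c(c(-c3ccc(C(F)(F)F)c(SCCNC(=O)C4CCCNC4)c3)nn2CC(O)CN2CCC(N3CCCC3=O)CC2)C1` goes one step further: piperidin-3-yl in place of 4-(dimethylamino)phenyl on a carbonyl carbon. The measured steps each swapped a single substituent on that aromatic ring, whereas here the whole ring is exchanged for a non-aromatic one, so they bear on this step only loosely. Still, a 1.1-fold lower number from compound 1 to compound 2 (0.02 log units; within the scatter), a 1.4-fold higher number from compound 1 to compound 3 (0.14 log units; within the scatter) and a 1.5-fold higher number from compound 2 to compound 3 (0.17 log units; within the scatter) all show that changes at this end of the molecule have so far left this assay almost untouched. A step of a 1.1-fold lower number from compound 3 to compound 4 (0.03 log units; within the scatter) is therefore expected, with a wider range than before. The estimate for compound 4 in this assay is 500 nM, lying between 150 nM and 2000 nM.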

Compound 4, half-maximal inhibitory concentration: 420 nM
Compound 4: the middle estimate sits 1.2-fold (0.08 log units) above what was measured; low and high end bracket the measured number.
By their numbers in this assay, from the lowest: compounds 2, 1, 4 and 3 (each within the scatter of the next).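

Until now only substituents on the aromatic ring had changed. Compound 4 shows that the whole ring can give way to piperidin-3-yl, a non-aromatic ring carrying a hydrogen-bond donor that 4-(dimethylamino)phenyl lacks, and still no step beyond the scatter appears in this assay (a 1.3-fold lower number from compound 3 to compound 4 (0.10 log units; within the scatter)), (a 1.2-fold higher number from compound 2 to compound 4 (0.07 log units; within the scatter)) and (a 1.1-fold higher number from compound 1 to compound 4 (0.04 log units; within the scatter)). Across these four compounds, then, an aromatic ring on this carbonyl carbon is not required to keep the number at this level, though nothing shown gives a reason for this flat result.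

Going by these compounds, whether a carboxylic acid, an open-chain amine or a small group such as methyl on this carbonyl carbon would behave alike stays open. Also open, on these data alone, is whether a cyclohexyl ring, which has no ring nitrogen, would match compound 4, and whether any group here can move this assay beyond the scatter.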